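A few compounds are considered here, and "the series" means these few. Any claim that something is new, unique, unknown or untested is made for them only; others in the source may bear on it.

The study concerns two measured compounds and one not yet measured, all sharing one core. Compound 1 `CC1(COC(=O)N2CC3COCC(C2)C3Oc2ncnc(Nc3ccc(C#N)cc3Cl)c2F)COC1` and compound 2 `CCC1(OC(=O)N2CC3COCC(C2)C3Oc2ncnc(Nc3ccc(C#N)cc3F)c2F)CC1` were both tested in a functional assay on HEK293 cells for agonist activity at Glucose-dependent insulinotropic receptor (Homo sapiens), read by cAMP accumulation, with a stated time of 30 min; on this read-out higher numbers stand for larger maximal responses and lower numbers for smaller maximal responses. In that assay compound 1 gives 41%, while compound 2 gives 89%. Among the measured compounds shown here, compound 2 thus stands highest of the two numbers known, and the number for compound 1 lies well below it, beyond the usual scatter of such measurements.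

Compound 3 `COCC1(OC(=O)N2CC3COCC(C2)C3Oc2ncnc(Nc3ccc(C#N)cc3F)c2F)CC1` is the next compound to be measured. Its relation to compound 2 is a single change: methoxy in place of methyl on a saturated chain carbon bound to a saturated ring carbon. The change is small in size, swapping a methyl for a methoxy on a saturated chain carbon bound to a saturated ring carbon, and leaves the rest of compound 2 untouched.

For the measured compounds named here, no measured pair in the set shows what such a swap does, so the expectation rests on compound 2 alone. Compound 3 is expected to stay near compound 2, with a step from a number 9 percentage points lower from compound 2 to compound 3 (within the scatter) that is not expected to go beyond the scatter. Compound 3 is therefore estimated at 80%, within a range from 55% to 100%.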

Compound 3, largest response reached (reported as percent of maximum), in percent of the reference or control that the assay uses: 62%
Compound 3: the middle estimate sits 18 percentage points above what was measured; measured number inside the range.
By their numbers in this assay, from the lowest: compound 1; then compound 3; then compound 2.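

In this assay, among the compounds shown here, putting methoxy in place of methyl on a saturated chain carbon bound to a saturated ring carbon gives a number 27 percentage points lower from compound 2 to compound 3 (beyond the scatter), the first step in the set that can be read at a single place. It shows that the maximal response is sensitive to this position, even to a change as small as 1-ethylcyclopropyl to 1-(methoxymethyl)cyclopropyl, while compound 3 still reaches 62% with the rest of compound 2 untouched. Nothing among the data shown explains this step.

The compounds shown leave open whether the step follows the entering oxygen or simply the longer chain, a question that a propyl group in place of the methoxymethyl would separate, while a hydroxymethyl or an aminomethyl group there would show how other heteroatoms fare at the same place. They also leave open whether the same swap would give a step of similar size on the other parts of the series, such as with the chlorine-bearing aniline of compound 1, which differs from compound 2 in more than one place.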